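Swapping 4-cyanophenyl for 2,4-dimethylphenyl on a sulfonamide nitrogen

A few compounds are considered here, and "the series" means these few. Any claim that something is new, unique, unknown or untested is made for them only; others in the source may bear on it.

Compound 1 `CCc1ccc(N(C2COC2)S(=O)(=O)c2ccc3c(c2)C(O)CC(C2CCOCC2)O3)cc1`: 2.63
Compound 2 `CC(C)CN(c1ccc(C#N)cc1)S(=O)(=O)c1ccc2c(c1)C(O)CC(C1CCOCC1)O2`: 3.07

In a physicochemical assay for lipophilicity, at pH 7.4 (a higher number here means a more lipophilic compound, a lower number a more polar compound), compound 2 at 3.07 stands highest of these two, and compound 1 lies lower by a gap beyond the scatter. Compound 3 `Cc1ccc(N(CC(C)C)S(=O)(=O)c2ccc3c(c2)C(O)CC(C2CCOCC2)O3)c(C)c1` has 2,4-dimethylphenyl in place of the 4-cyanophenyl of compound 2 on a sulfonamide nitrogen (2,4-dimethylphenyl in place of 4-cyanophenyl on a sulfonamide nitrogen). For the measured compounds named here, no two measured compounds differ in just one place, so the expectation rests on this change alone. An upward step beyond the scatter is expected, estimated as a number 0.83 log units higher from compound 2 to compound 3 (beyond the scatter) in this assay. For compound 3 the estimate is 3.9 with an expected range from 3.4 to 4.4.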

Compound 3, distribution coefficient: 4.19
Compound 3: middle estimate off by 0.29 log units, on the low side; the measured number falls inside the stated range.
By their numbers in this assay, from the lowest: compound 1; then compound 2; then compound 3.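

For the compounds shown here, this is the first pair that differs in only one place. In this assay putting 2,4-dimethylphenyl in place of 4-cyanophenyl on the sulfonamide nitrogen gives a number 1.12 log units higher from compound 2 to compound 3 (beyond the scatter) and so shows that this position can move the number by a large step, even though a six-membered aromatic ring of carbon stays there and only the substituents on it change. Nothing measured here explains the size of the step. The compounds shown leave open how much each methyl contributes alone, and where a 4-aminophenyl or 4-carboxyphenyl group would fall.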